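Swapping a Carboxy Side Chain for a Dimethylaminoethyl Group

The compounds below may be only part of what the source reports. "The series", "measured", "known", "first", "only" and "open" are said of these compounds alone.

In a functional assay on HeLa cells (Homo sapiens) for antiproliferative activity, read by CCK-8 assay, with a stated time of 48 h (on this read-out higher numbers stand for weaker inhibition and lower numbers for stronger inhibition), compound 2 `COc1ccc(/C=C\c2cc(OC)c(OC)c(OC)c2)cc1OCc1ccc(CN[C@H](C(=O)O)[C@H](C)O)cc1` gives only a limit (> 10000 nM). Compound 1 `COc1ccc(/C=C\c2cc(OC)c(OC)c(OC)c2)cc1OCc1ccc(CN2CCCC[C@@H]2C(=O)O)cc1` also gives only a limit (> 10000 nM). Between these two lies a step that the two limits leave unreadable from compound 1 to compound 2 and so this step offers no size to build on. Compound 2 therefore sits at the limit of > 10000 nM in this assay, at which 2 of the 3 values shown sit, and has no exact value. Compound 3 `COc1ccc(/C=C\c2cc(OC)c(OC)c(OC)c2)cc1OCc1ccc(CN2CCCCC2C(=O)NCCNC(=O)OC(C)(C)C)cc1` carries no free carboxy group and gives a true number (2000 nM).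

Compound 4 `COc1ccc(/C=C\c2cc(OC)c(OC)c(OC)c2)cc1OCc1ccc(CNCCN(C)C)cc1` has not yet been measured. Its difference from compound 2 is this: 2-(dimethylamino)ethyl in place of 1-carboxy-2-hydroxypropyl on an amine nitrogen In short, 2-(dimethylamino)ethyl stands in place of 1-carboxy-2-hydroxypropyl on an amine nitrogen, so the carboxy group is lost.

Among just these three measured compounds, the two with a carboxy group sit at the limit, and none goes against this. The expectation rests on that thin comparison, with compound 3 (2000 nM) as the nearest guide. The expected at least 6.6-fold lower number from compound 2 to compound 4 (0.82 log units; beyond the scatter) points towards stronger inhibition. Compound 4 is estimated at 1500 nM (300 nM to 8000 nM).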

Compound 4, half-maximal inhibitory concentration: 9400 nM
Estimate against measurement, compound 4: 6.3-fold (0.80 log units) below, and the stated range ends below it.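

In this assay compound 4 gives an exact value of 9400 nM, so on this amine nitrogen a side chain without a carboxy group can give a true number, as compound 3 did on its own side chain. Even so, the change reads only as an at least 1.0-fold lower number from compound 2 to compound 4 (0.02 log units; that floor lies within the scatter), and the wider change reads the same, an at least 1.0-fold lower number from compound 1 to compound 4 (0.02 log units; that floor lies within the scatter), so losing the carboxy group shows no gain beyond the scatter here. On these data alone, the real size of the first step stays unknown because compound 2 gives only a limit: the limit of > 10000 nM in this assay, at which 2 of the 4 values shown sit.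

As far as these compounds go, it remains open how a shorter-ended 2-aminoethyl group or a longer 3-(dimethylamino)propyl chain would read at this place. Also open, from the compounds shown here alone, is which part of compound 3 goes with its value of 2000 nM, whether its amide or its carbamate end.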